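Anilinopyrimidine benzothiazole series: isopropyl to nitro swap

The compounds below may be only part of what the source reports. "The series", "measured", "known", "first", "only" and "open" are said of these compounds alone.

Three compounds of the shared core have been run in a functional assay on PC-3 cells (Homo sapiens) for antiproliferative activity, read by MTT assay, with a stated time of 48 h; on this read-out lower numbers stand for stronger inhibition and higher numbers for weaker inhibition. Compound 1 `Cc1cnc(Nc2ccc(C(C)C)cc2)nc1Nc1nc2ccccc2s1` carries an isopropyl group on the outer aromatic ring. In this assay compound 1 gives > 50000 nM, which is a limit of the assay and not a number. Going by the values given here, compound 2 `Cc1ccc2nc(Nc3nc(Nc4ccc(S(N)(=O)=O)cc4)ncc3C)sc2c1` is the only member with a measured value, giving 2710 nM in this assay. Compound 3 `NS(=O)(=O)c1ccc(Nc2ncc(F)c(Nc3nc4ccccc4s3)n2)cc1` gives > 50000 nM in this assay, again a limit. Thus compound 1 stands at the limit of > 50000 nM in this assay, at which 2 of the 3 values shown sit, and no ordering between compound 1 and compound 3 can be read from these two limits.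

Compound 4 `Cc1cnc(Nc2ccc([N+](=O)[O-])cc2)nc1Nc1nc2ccccc2s1` is the next entry to be measured. It differs from compound 1 only by nitro in place of isopropyl on an aromatic carbon. Among the compounds with values here, no measured pair isolates this change, so the expected step from compound 1 to compound 4 is taken as an at least 1.6-fold lower number from compound 1 to compound 4 (0.22 log units; that floor lies within the scatter), a move down from the limit that may or may not exceed the scatter. Compound 4 is therefore estimated at 30000 nM, within 5000 nM to 60000 nM.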

Compound 4, half-maximal inhibitory concentration: > 50000 nM
Compound 4 gave a limit, no number; the forecaster's own chance of this, stated with the estimate: 50%; at least 1.6-fold (0.22 log units) between middle value and limit.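

Compound 1 and compound 4 both stand at a limit in this assay and not at a number, so no step between them can be read: the limit of > 50000 nM in this assay, at which 3 of the 4 values shown sit.

Whether nitro in place of isopropyl changes antiproliferative activity at all remains open with the compounds shown.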